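Swapping a dichlorophenyl urea end for a methylphenyl one

The source may hold more compounds than are shown below. What is called first, only, known or untested is meant among the compounds shown, and "the series" means these compounds.

Compound 3 `CCN(CC)CCCNc1nc(-c2ccc(NC(=O)Nc3ccc(Cl)cc3Cl)cc2)nc2c(Cl)c(Cl)sc12` gives 1170 nM in a functional assay on NCI-H460 cells (Homo sapiens) for cytotoxicity, read by MTT assay, with a stated time of 72 h (a higher number here means a weaker inhibitor, a lower number a stronger inhibitor), the highest of the three numbers measured. Compound 2 `CCN(CC)CCCNc1nc(-c2ccc(NC(=O)Nc3ccc(Cl)cc3)cc2)nc2c(Cl)c(Cl)sc12` gives 270 nM, and compound 1 `Cc1ccc(NC(=O)Nc2ccc(-c3nc(NCCCN(C)C)c4sc(Cl)c(Cl)c4n3)cc2)cc1` gives 1110 nM. Among the compounds with values here, the one measured step, a 4.3-fold higher number from compound 2 to compound 3 (0.64 log units; beyond the scatter), came from adding a chloro group to the urea end. Compound 4 `CCN(CC)CCCNc1nc(-c2ccc(NC(=O)Nc3ccc(C)cc3)cc2)nc2c(Cl)c(Cl)sc12` reverses that addition and also replaces the remaining chloro with methyl: 4-methylphenyl in place of 2,4-dichlorophenyl on an amide-type nitrogen. Compound 1 carries the same methylphenyl urea as compound 4 but a different amine chain, so its value hints at what this end alone tolerates. Taken together, a moderate move downward is expected, a 2.3-fold lower number from compound 3 to compound 4 (0.37 log units; beyond the scatter), placing compound 4 at an estimated 500 nM, within the range 200 nM to 1500 nM.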

Compound 4, half-maximal inhibitory concentration: 1240 nM
The estimate for compound 4 lay 2.5-fold (0.39 log units) below the measured number, within the range that was stated.
By their numbers in this assay, from the lowest: compound 2; then compounds 1, 3 and 4 (each within the scatter of the next).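

In this assay, 4-methylphenyl and 2,4-dichlorophenyl on the amide-type nitrogen cannot be told apart, with a 1.1-fold higher number from compound 3 to compound 4 (0.03 log units; within the scatter). Methyl in place of chloro on the aromatic carbon gives a 4.6-fold higher number from compound 2 to compound 4 (0.66 log units; beyond the scatter), so among the diethylamino compounds, compound 2 alone stands apart. The amine chain does not separate the methyl-bearing pair either: diethylamino in place of dimethylamino gives a 1.1-fold higher number from compound 1 to compound 4 (0.05 log units; within the scatter). Within the data shown here, nothing available explains why the single chloro of compound 2 stands apart. Also open, on these data alone, is how a 4-fluorophenyl or 4-methoxyphenyl end, or a longer amine chain, would read in this assay.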